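This account rests on a few compounds, and the source may have more. Where it says the series, first, only, none or still open, it means among the compounds named here.

Measured so far in a functional assay on K562 cells (Homo sapiens) for cytotoxicity, read by MTT assay, with a stated time of 72 h; on this read-out higher numbers stand for weaker inhibition and lower numbers for stronger inhibition:
compound 1 `Cc1ccc(NN=C(c2nc3ccccc3[nH]2)c2nc3ccccc3[nH]2)cc1` gives 160000 nM
compound 2 `COc1ccc(NN=C(c2nc3ccccc3[nH]2)c2nc3ccccc3[nH]2)cc1` gives 117000 nM

Compound 2 stands with the lower of the two numbers shown, but a 1.4-fold lower number from compound 1 to compound 2 (0.14 log units; within the scatter) falls within the scatter, so compound 2 and compound 1 are not separated in this assay.

Compound 3 `Clc1ccc(NN=C(c2nc3ccccc3[nH]2)c2nc3ccccc3[nH]2)cc1` differs from compound 2 by chloro in place of methoxy on an aromatic carbon. Within the data shown here, no measured step swaps chloro for methoxy; the only step at hand, a 1.4-fold lower number from compound 1 to compound 2 (0.14 log units; within the scatter), is small. Nothing in the series therefore points to a shift beyond the scatter, and for compound 3 the expected step is a 1.1-fold lower number from compound 2 to compound 3 (0.03 log units; within the scatter). Compound 3 is estimated at 110000 nM, expected range 50000 nM to 250000 nM.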

Compound 3, half-maximal inhibitory concentration: 200000 nM
Compound 3: the middle estimate sits 1.8-fold (0.26 log units) below what was measured, and the stated range covers the measured number.
By their numbers in this assay, from the lowest: compounds 2, 1 and 3 (each within the scatter of the next).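

At this place on the aromatic ring, para to a large group, chloro gives no separation from either earlier group in this assay: a 1.7-fold higher number from compound 2 to compound 3 (0.23 log units; within the scatter) and a 1.3-fold higher number from compound 1 to compound 3 (0.10 log units; within the scatter) both stay within the scatter. The swap of methoxy for chloro also removes a hydrogen-bond acceptor and one heavy atom, and this leaves compound 3 unseparated from compound 2. No measured evidence accounts for these three values lying together.

Going by these compounds, whether an amine or a carboxylic acid at this place would move the number beyond the scatter remains open. So does the outcome of any change elsewhere on the shared core.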